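The source may report more compounds than this note shows. Statements on the series, on what has been measured and on what is new or still open speak of the compounds shown alone.

Of the compounds shown here, two have been tested in a functional assay on the whole organism for inhibition, with Mus musculus as the target, with a stated time of 1 h, at a dose of 30 mg/kg by the intraperitoneal route; on this read-out higher numbers stand for more inhibition at the one dose given (going by the name of the read-out) and lower numbers for less inhibition. Compound 1, `O=C(/C=C/C1=Cc2ccccc2OC1)c1ccccc1F`, gives 64.4% in this assay, and compound 2, `O=C(/C=C/C1=Cc2ccccc2OC1)c1ccc(Cl)cc1`, gives 56.1% in this assay. Within the data shown here, the one step between them, a number 8.3 percentage points lower from compound 1 to compound 2 (within the scatter), lies within the scatter, so the two numbers cannot be told apart. On the numbers shown, compound 2 stands lowest of the two, with compound 1 as its nearest neighbour within the scatter.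

Compound 3, `CCc1ccc(C(=O)/C=C/C2=Cc3ccccc3OC2)cc1`, has not yet been measured in this assay. It differs from compound 2 in one place: ethyl in place of chloro on an aromatic carbon. Among the measured compounds shown here, no measured step involves an ethyl group, so the only guidance is the step from compound 1 to compound 2, which lies within the scatter and suggests that swapping one group for another on this ring has left the read-out largely unchanged so far. No step beyond the scatter is therefore expected here. The step from compound 2 to compound 3 is estimated at a number 0.1 percentage points lower from compound 2 to compound 3 (within the scatter). Compound 3 is expected to give about 56% in this assay, within a range from 36% to 76%.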

Compound 3, a percentage reported as inhibition, in the whole organism at one dose (the size of the read-out at that dose, not a potency): 68.1%
Estimate against measurement, compound 3: 12.1 percentage points below; measured number inside the range.
By their numbers in this assay, from the lowest: compounds 2, 1 and 3 (each within the scatter of the next, the first and the last beyond it).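

In this assay, among these compounds, putting ethyl in place of chloro para to a large group gives the first step that clears the usual scatter, with a number 12 percentage points higher from compound 2 to compound 3 (beyond the scatter). Among the compounds shown here, the earlier step, a number 8.3 percentage points lower from compound 1 to compound 2 (within the scatter), gave no such sign, so this is the first indication that the group at this place on the ring can change the read-out, if only modestly. The swap exchanges one chlorine atom for two carbon atoms, with no ring, hydrogen-bond donor, hydrogen-bond acceptor or net charge on either side, and nothing available here explains why the two groups differ.

The compounds shown leave open whether a longer chain, such as propyl or butyl, at this same place would carry the number further or whether a smaller methyl group would fall nearer to compound 2 or to compound 3. Going by these compounds, it also remains open how an amine or a carboxylic acid at this place would read out, and whether the difference between ethyl and chloro would hold at other doses.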